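This account rests on a few compounds, and the source may have more. Where it says the series, first, only, none or still open, it means among the compounds named here.

Compound 1 `CN1CCC[C@H]1[C@H]1COc2cc(N)ccc2O1`: 8600 nM
Compound 2 `CN1CCC[C@H]1[C@@H]1COc2cc(O)ccc2O1`: 1900 nM

Of the two numbers measured in an assay on membranes from HEK293 cells for displacement of a labelled ligand from Neuronal acetylcholine receptor; alpha3/beta4 (Homo sapiens), with a stated time of 5 min (on this read-out lower numbers stand for stronger inhibition and higher numbers for weaker inhibition), compound 2 gives the lower one, 1900 nM, and compound 1 gives 8600 nM. These two compounds differ in more than one place, so their gap cannot be tied to any single change. Compound 3 `CN1CCC[C@H]1[C@H]1COc2cc(O)ccc2O1` has not yet been measured. Compared with compound 2, (the two compounds have the same atoms and bonds and differ only in configuration as drawn: 1 of 2 stereo elements differ; a stereocentre at a saturated ring carbon is drawn R in compound 2 and S in compound 3). Going by the values given here, no measured pair here differs only in configuration at this centre, so the data do not show how large such a step is. A change in configuration alone is expected to give a step of moderate size, more likely towards a higher number than a lower one, and the expected step is a 2.1-fold higher number from compound 2 to compound 3 (0.32 log units; beyond the scatter). For compound 3 the estimate in this assay is 4000 nM, within a range from 1000 nM to 16000 nM.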

Compound 3, inhibition constant: 6000 nM
Estimate against measurement, compound 3: 1.5-fold (0.18 log units) below; measured number inside the range.
By their numbers in this assay, from the lowest: compound 2; then compounds 3 and 1 (each within the scatter of the next).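

In this assay, the configuration at one saturated ring carbon now has a measured size, a 3.2-fold higher number from compound 2 to compound 3 (0.50 log units; beyond the scatter), and the R form, compound 2, gives the lower number. This step can be laid on that single stereocentre alone, because nothing else separates the pair: the fact that compounds 2 and 3 differ only in the configuration as drawn. Hydroxy in place of amino on the aromatic carbon, with the configuration held the same, gives a 1.4-fold lower number from compound 1 to compound 3 (0.16 log units; within the scatter), so the two groups cannot be told apart here.

From the compounds shown here alone, it remains open whether amino would show the same dependence on configuration at the ring carbon as hydroxy does. Going by these compounds, it is also open whether the configuration step would keep its size with another group on that aromatic carbon, such as a methoxy group or a carboxylic acid.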